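This account rests on a few compounds, and the source may have more. Where it says the series, first, only, none or still open, it means among the compounds named here.

Measured so far:
compound 1 `O=C(Nc1ccc(Oc2cc(O)ncn2)cc1)Nc1cccc(C(F)(F)F)c1` — 3200 nM
compound 2 `CNc1cc(Oc2ccc(NC(=O)Nc3cccc(C(C)(C)C)c3)cc2)ncn1` — 40 nM
compound 3 `CCc1cccc(NC(=O)Nc2ccc(Oc3cc(NC)ncn3)cc2)c1` — 200 nM

In an assay on isolated protein for inhibition of serine/threonine-protein kinase TNNI3K (Homo sapiens) (on this read-out lower numbers stand for stronger inhibition and higher numbers for weaker inhibition), compound 1 gives the highest of the three numbers; compound 3 sits closer to it, compound 2 furthest. Compound 4 `CC(C)(O)CNc1cc(Oc2ccc(NC(=O)Nc3cccc(C(F)(F)F)c3)cc2)ncn1` differs from compound 1 in one place: (2-hydroxy-2-methylpropyl)amino in place of hydroxy on an aromatic carbon. For the measured compounds named here, no measured pair isolates this change. Going by the values given here, the only single step, a 5.0-fold higher number from compound 2 to compound 3 (0.70 log units; beyond the scatter), concerns the group on the other aromatic ring, not the pyrimidine position changed here. Compounds 2 and 3, which carry an amino group at that position but also differ from compound 1 elsewhere, show far lower numbers, so a substantial fall is expected, a 21-fold lower number from compound 1 to compound 4 (1.33 log units; beyond the scatter). Compound 4 is estimated at 150 nM, within 30 nM to 800 nM.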

Compound 4, half-maximal inhibitory concentration: 40 nM
Estimate against measurement, compound 4: 3.8-fold (0.57 log units) above; measured number inside the range.
By their numbers in this assay, from the lowest: compounds 2 and 4 (each within the scatter of the next); then compound 3; then compound 1.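

Changing hydroxy to (2-hydroxy-2-methylpropyl)amino on this aromatic carbon gives an 80-fold lower number from compound 1 to compound 4 (1.90 log units; beyond the scatter) in this assay and is a clean test of this position. With the rest of the molecule held constant, this one position clearly has a large influence on the number, something compounds 2 and 3 could not show, as they also differ from compound 1 elsewhere. Nothing shown here explains why the number falls.

Going by these compounds, it remains open whether the amino nitrogen, the chain's hydroxy group or both matter. A plain amine or a methoxy group at this position in compound 4 would help separate these possibilities.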